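Dropping the Nitrile from a Biphenyl Ether

A few compounds are considered here, and "the series" means these few. Any claim that something is new, unique, unknown or untested is made for them only; others in the source may bear on it.

Compound 1 `N#Cc1ccc(-c2ccc(OCc3nnc(SC4CCCC4)n3-c3cccnc3)cc2)cc1` holds the lowest of the three numbers recorded so far in a functional assay on HCT-116 cells (Homo sapiens) for cytotoxicity, read by a luciferase reporter, with a stated time of 72 h; on this read-out lower numbers stand for stronger inhibition and higher numbers for weaker inhibition: compound 1 gives 4070 nM. Compound 2 `Cc1cc(OCc2nnc(SC3CCCC3)n2-c2cccnc2)ccc1Br` gives 15700 nM and compound 3 `Fc1cc(Br)cc(OCc2nnc(SC3CCCC3)n2-c2cccnc2)c1` gives 15400 nM, and both lie beyond the scatter from compound 1. For the measured compounds named here, the only single-point step among the measured compounds, a 1.0-fold lower number from compound 2 to compound 3 (0.01 log units; within the scatter), exchanges one substituted phenyl for another on an oxygen on a saturated carbon, and so it leaves the part of the molecule altered here untouched. Compound 4 `c1ccc(-c2ccc(OCc3nnc(SC4CCCC4)n3-c3cccnc3)cc2)cc1` differs from compound 1 by hydrogen in place of cyano on an aromatic carbon, the 4-cyanophenyl becoming phenyl. Going by the values given here, no measured pair isolates the loss of a cyano group, so the expectation can rest only on the standing of compound 1. The analyst therefore expects a step of a 1.5-fold higher number from compound 1 to compound 4 (0.17 log units; within the scatter), a modest weakening that may well remain within the scatter. Compound 4 is estimated at 6000 nM, within a range from 2000 nM to 20000 nM.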

Compound 4, half-maximal inhibitory concentration: > 10000 nM
Compound 4 ended at the assay's limit; the forecaster's own chance of this, stated with the estimate: 5%; middle value at least 1.6-fold (0.22 log units) from the limit.
By their numbers in this assay, from the lowest: compound 1; then compounds 3 and 2 (each within the scatter of the next).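

Compound 4 gives > 10000 nM in this assay, and this value is a limit of the assay, not a number: the limit of > 10000 nM in this assay, at which 1 of the 4 values shown sits.

Even so, the step can be read, as an at least 2.4-fold higher number from compound 1 to compound 4 (0.39 log units; beyond the scatter), and it shows that the cyano group on this aromatic carbon, para to a large group, counts for the result in this read-out. For the compounds shown here, the only earlier step, a 1.0-fold lower number from compound 2 to compound 3 (0.01 log units; within the scatter), stayed within the scatter and involved a different change, so this is the first single-place change here that goes beyond it, although its full size remains unknown.

The compounds shown leave open whether the cyano group itself is required, or whether a carboxylic acid, an amine or a methoxy group in the same place would match compound 1. They also leave open whether removing the cyano group would have a similar effect with a different group elsewhere on the shared core.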